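Adding a Large Group on Oxygen to Compound 2

This account rests on a few compounds, and the source may have more. Where it says the series, first, only, none or still open, it means among the compounds named here.

In an ADME assay on A549 cells (Homo sapiens) for cytotoxicity, read by MTT assay (on this read-out lower numbers stand for higher toxicity in this test and higher numbers for lower toxicity in this test), compound 1 `CCCCCCCCNc1nc(=O)n([C@H]2C[C@H](O)[C@@H](CO)O2)cc1C` gives 90000 nM. For the measured compounds named here, compound 2 `CCCCCCCCCCCCNc1nc(=O)n([C@H]2C[C@H](O)[C@@H](CO)O2)cc1C` gives 158000 nM, which stands within the scatter of compound 1 and is one of only two numbers available. Compound 3 `CCCCCCCCCCCCNc1nc(=O)n([C@H]2C[C@H](OC(=O)OCCOCCOCCO)[C@@H](CO)O2)cc1C` keeps the chain of compound 2 and differs from it by a group of 12 heavy atoms (7 carbon, 5 oxygen; no ring) in place of a hydrogen atom, on an oxygen on a saturated carbon. Going by the values given here, the single measured step, a 1.8-fold higher number from compound 1 to compound 2 (0.24 log units; within the scatter), lies on the chain rather than at this oxygen, and no measured step touches that oxygen. That step therefore gives only weak guidance, and nothing in the data points to a shift in this assay, so none beyond the scatter is expected. The expected change is a 1.2-fold lower number from compound 2 to compound 3 (0.08 log units; within the scatter). For compound 3 the estimated value is 130000 nM, with an expected range of 45000 nM to 350000 nM.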

Compound 3, half-maximal cytotoxic concentration: 90000 nM
Beside the measured number, compound 3's estimate is 1.4-fold (0.16 log units) above it; the range from low to high includes it.
By their numbers in this assay, from the lowest: compounds 1, 3 and 2 (each within the scatter of the next).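

In this assay, for the compounds shown here, the first measured change at this oxygen on a saturated carbon gives a 1.8-fold lower number from compound 2 to compound 3 (0.24 log units; within the scatter) and so stays within the scatter. Going by these compounds alone, the chain step between the earlier compounds could not show this: the oxygen accepts a group of 12 heavy atoms, with no ring and 5 hydrogen-bond acceptors, in place of a hydrogen atom without a step beyond the scatter in this test. Nothing measured here gives a reason for this result.

The compounds shown do not tell whether a smaller acetyl group on the same oxygen, or an amine or a carboxylic acid at the far end of the entering group, would also stay within the scatter. They also leave open whether the same group gives a similar reading on the octyl chain of compound 1.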